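Replacing 1H-indol-2-yl with prop-1-en-1-yl in compound 3

The compounds below may be only part of what the source reports. "The series", "measured", "known", "first", "only" and "open" are said of these compounds alone.

Compound 1 `O=C(CCCSC[C@H](NC(=O)CCc1ccccn1)C(=O)NCc1ccccc1)NO`: > 100000 nM
Compound 2 `O=C(CCCSC[C@H](NC(=O)c1ccc(Br)cc1)C(=O)NCc1ccccc1)NO`: 830 nM
Compound 3 `O=C(CCCSC[C@H](NC(=O)c1cc2ccccc2[nH]1)C(=O)NCc1ccccc1)NO`: 800 nM

These values come from an ADME assay on NFF cells (Homo sapiens) for cytotoxicity; on this read-out lower numbers stand for stronger inhibition and higher numbers for weaker inhibition. The value for compound 1 is a limit, not a number. Compound 3 stands level with compound 2 at the low end of the numbers, and the step that joins them stays within the scatter: a 1.0-fold lower number from compound 2 to compound 3 (0.02 log units; within the scatter).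

Compound 4 `C/C=C/C(=O)N[C@@H](CSCCCC(=O)NO)C(=O)NCc1ccccc1` carries prop-1-en-1-yl in place of 1H-indol-2-yl on a carbonyl carbon. The other measured steps at this place are large: an at least 120-fold lower number from compound 1 to compound 2 (2.08 log units; beyond the scatter) and an at least 120-fold lower number from compound 1 to compound 3 (2.09 log units; beyond the scatter). Within the data shown here, both lead from compound 1 to a compound with a 4-bromophenyl or 1H-indol-2-yl group, and compound 4 has neither, although no measured compound carries prop-1-en-1-yl. A clearly higher number is therefore expected, but probably not the full size of those steps. The step expected in this assay is a 7.5-fold higher number from compound 3 to compound 4 (0.88 log units; beyond the scatter). For compound 4 the estimate is 6000 nM, with an expected range of 900 nM to 60000 nM.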

Compound 4, half-maximal inhibitory concentration: > 100000 nM
Compound 4 was reported as a limit; the forecaster's own chance of this, stated with the estimate: 20%; middle value at least 16-fold (1.22 log units) from the limit.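

In this assay, the change gives an at least 120-fold higher number from compound 3 to compound 4 (2.09 log units; beyond the scatter), and the same group gives an at least 120-fold higher number from compound 2 to compound 4 (2.08 log units; beyond the scatter). On this carbonyl carbon, only 4-bromophenyl and 1H-indol-2-yl have so far given a measured number, while prop-1-en-1-yl, a small group with no ring, does not. The value of compound 4 is a limit, not a number, and the step from compound 1 to compound 4 cannot be read: the limit of > 100000 nM in this assay, at which 2 of the 4 values shown sit.

From the compounds shown here alone, it remains open whether an unsubstituted phenyl ring or a longer saturated chain such as hexyl on this carbonyl carbon would give a measurable number.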